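Aryl swap at the exocyclic double bond of compound 2

This account rests on a few compounds, and the source may have more. Where it says the series, first, only, none or still open, it means among the compounds named here.

Among the compounds with values here, compound 2 `Cc1cccc2c1N(CC(=O)O)C/C(=C\c1ccccc1Cl)C2=O` has the higher of the two numbers so far in an assay on HL-60 cells for inhibition of glutathione S-transferase P (Homo sapiens), read by spectrophotometry, tested at 20 uM (on this read-out higher numbers stand for more inhibition at the one concentration tested (going by the name of the read-out) and lower numbers for less inhibition), giving 51.9%; its nearest neighbour is compound 1 `Cc1ccc(/C=C2\CN(CC(=O)O)c3c(C)cccc3C2=O)cc1`, which in this assay gives 46.8%, and the step of a number 5.1 percentage points higher from compound 1 to compound 2 (within the scatter) lies within the scatter. Compound 3 `COc1ccc(/C=C2\CN(CC(=O)O)c3c(C)cccc3C2=O)cc1` is not yet measured. The change from compound 2 to compound 3 is 4-methoxyphenyl in place of 2-chlorophenyl on a double-bonded chain carbon bound to a double-bonded ring carbon. Within the data shown here, the only measured step at this position, the one from compound 1 to compound 2, exchanged one aryl group for another and moved the number by an amount within the scatter, so another exchange of the aryl group at the same place is expected to give at most a small step in this assay. For compound 3 the expected step is a number 4.9 percentage points lower from compound 2 to compound 3 (within the scatter). The estimate for compound 3 in this assay is 47%, with a range from 30% to 63%.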

Compound 3, a percentage reported as inhibition, at one concentration (the size of the read-out at that concentration, not a potency): 31.5%
Estimate against measurement, compound 3: 15.5 percentage points above; the measured number falls inside the stated range.
By their numbers in this assay, from the lowest: compound 3; then compounds 1 and 2 (each within the scatter of the next).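

In this assay the aryl group on the double-bonded chain carbon no longer looks freely exchangeable: 4-methoxyphenyl in place of 2-chlorophenyl gives a number 20.4 percentage points lower from compound 2 to compound 3 (beyond the scatter) and so moves the number beyond the scatter, which the earlier exchange did not do. The smaller change of methoxy in place of methyl on an aromatic carbon also gives a number 15.3 percentage points lower from compound 1 to compound 3 (beyond the scatter) in the same assay, so a single group on that aryl ring is enough to shift the number. No measured evidence bears on the reason for either step.

The compounds shown do not separate the identity of the group from where it sits on the aryl ring, which a 2-methoxyphenyl or a 4-chlorophenyl group would address. As far as these compounds go, whether a hydroxyl or an amine on that aromatic carbon would read closer to methyl or to methoxy also stays open.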